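Swapping Cyclopentyl for Isopropyl: What Should Happen?

The source may hold more compounds than are shown below. What is called first, only, known or untested is meant among the compounds shown, and "the series" means these compounds.

Compound 1 `N=C(NC(=N)NC1CCCC1)Nc1ccc(C(F)(F)F)cc1`: 3700 nM
Compound 2 `CC(C)CNC(=N)NC(=N)Nc1ccc(F)cc1F`: 40800 nM

These two values come from a functional assay on T-24 cells (Homo sapiens) for antiproliferative activity, read by MTT assay, with a stated time of 72 h (on this read-out higher numbers stand for weaker inhibition and lower numbers for stronger inhibition), so the lower number marks the stronger compound. Compound 1 stands lowest of the two, and the gap up to compound 2 lies beyond the usual scatter. The two compounds differ in more than one place, so that gap cannot be pinned on any single change.

Compound 3 `CC(C)NC(=N)NC(=N)Nc1ccc(C(F)(F)F)cc1` has not yet been measured. It carries isopropyl in place of cyclopentyl on an amine nitrogen and otherwise matches compound 1. For the measured compounds named here, no measured pair isolates this swap, so any forecast is tentative. A higher number is expected, and the estimated step of a 3.2-fold higher number from compound 1 to compound 3 (0.51 log units; beyond the scatter) would probably lie beyond the scatter. For compound 3 the estimated value is 12000 nM, with an expected range of 4500 nM to 30000 nM.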

Compound 3, half-maximal inhibitory concentration: 4800 nM
Beside the measured number, compound 3's estimate is 2.5-fold (0.40 log units) above it; the measured number falls inside the stated range.
By their numbers in this assay, from the lowest: compounds 1 and 3 (each within the scatter of the next); then compound 2.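

For the compounds shown here, this pair is the first to isolate the swap of cyclopentyl for isopropyl on an amine nitrogen, and in this assay it gives a 1.3-fold higher number from compound 1 to compound 3 (0.11 log units; within the scatter), so the two compounds cannot be told apart on this read-out. At this position, then, the five-membered carbon ring can be replaced by isopropyl, which has no ring and fewer carbons, without a change larger than repeat measurements would show. Nothing measured here explains why these two groups read alike.

Still open, as far as these compounds go, is whether a larger group at this nitrogen, such as a cyclohexyl ring or a longer chain, or one bearing a carboxylic acid, would also leave the number in place. From the compounds shown here alone, it is also open whether the swap would read the same on a core carrying fluorine instead of trifluoromethyl.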